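The compounds below may be only part of what the source reports. "The series", "measured", "known", "first", "only" and "open" are said of these compounds alone.

Measured compounds in a functional assay on HEK293 cells for agonist activity at G-protein coupled receptor 39 (Homo sapiens), read by scintillation proximity assay and inositol phosphate accumulation, with a stated time of 75 min; on this read-out higher numbers stand for an effect only at larger amounts of compound and lower numbers for an effect already at smaller amounts:
- compound 1 `Cc1nn(-c2ncnc3nc[nH]c23)c2c1C(OCc1ccc(C(C)C)cc1)CC(=O)N2`, compound 1 gives 1690 nM
- compound 2 `Cc1nn(-c2ncnc3nc[nH]c23)c2c1C(OCCn1nccc1C)CC(=O)N2`, compound 2 gives 1620 nM
- compound 3 `COc1ccc(CCOC2CC(=O)Nc3c2c(C)nn3-c2ncnc3nc[nH]c23)cc1`, compound 3 gives 70 nM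

Compound 3 stands at the lowest number of the three; its steps to both others, a 24-fold lower number from compound 1 to compound 3 (1.38 log units; beyond the scatter) and a 23-fold lower number from compound 2 to compound 3 (1.36 log units; beyond the scatter), lie beyond the scatter, so it is the most potent here. Compound 4 `Cc1nn(-c2ncnc3nc[nH]c23)c2c1C(OCc1ccccc1Cl)CC(=O)N2` differs from it by 2-chlorophenyl in place of 4-methoxybenzyl on a saturated chain carbon bound to an oxygen on a saturated carbon. The step bearing most directly is the reverse of a 24-fold lower number from compound 1 to compound 3 (1.38 log units; beyond the scatter): compound 1 also carries an aryl group directly on the chain carbon bound to the ether oxygen, and compound 4 returns to that arrangement. A large rise in number toward the level of compound 1 is therefore expected, a 17-fold higher number from compound 3 to compound 4 (1.23 log units; beyond the scatter). Compound 4 is estimated at 1200 nM, within 350 nM to 4000 nM.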

Compound 4, half-maximal effective concentration: 47 nM
Beside the measured number, compound 4's estimate is 26-fold (1.41 log units) above it, and the stated range ends above it.
By their numbers in this assay, from the lowest: compounds 4 and 3 (each within the scatter of the next); then compounds 2 and 1 (each within the scatter of the next).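

In this assay, an aryl group directly on the saturated chain carbon bound to the ether oxygen proves compatible with a low number (a 36-fold lower number from compound 1 to compound 4 (1.56 log units; beyond the scatter)), so the identity of that aryl group matters here, not its direct attachment alone. The change from 2-(4-methoxyphenyl)ethyl to 2-chlorobenzyl stays within the scatter (a 1.5-fold lower number from compound 3 to compound 4 (0.17 log units; within the scatter)), while the step from the pyrazole-bearing group is large (a 34-fold lower number from compound 2 to compound 4 (1.54 log units; beyond the scatter)). Nothing available accounts for these steps.

On these data alone, whether the chlorine or its place on the ring carries this result remains open: an unsubstituted phenyl or a 4-chlorophenyl here would separate the two.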